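The compounds below may be only part of what the source reports. "The series", "measured", "known", "first", "only" and "open" are said of these compounds alone.

Among the measured compounds shown here, in an in vivo ADME assay on the whole organism (strain Sprague-Dawley) for pharmacokinetics, with Rattus norvegicus as the target, at a dose of 2 mg/kg by the oral route (a lower number here means that a smaller share of the oral dose reaches the circulation, a higher number that a larger share of the oral dose reaches the circulation), compound 1 `Cc1cc(CCC(=O)O)ccc1-c1noc(-c2ccc(OC(C)C)c(C#N)c2)n1` gives 53%, the lower of the two numbers so far. Compound 2 `Cc1nc(CCC(=O)O)ccc1-c1noc(-c2ccc(OC(C)C)c(C#N)c2)n1` gives 93%, which lies beyond the scatter from it. Compound 3 `Cc1cc(CCC(=O)O)ccc1-c1noc(-c2ccc(OC(C)C)c(C(F)(F)F)c2)n1` keeps the core of compound 1 and changes one group: trifluoromethyl in place of cyano on an aromatic carbon. In words, trifluoromethyl stands in place of cyano on an aromatic carbon. For the measured compounds named here, no measured pair shows this change, so the expectation is loose, with no clear direction and no step beyond the scatter in this assay. The expected change is a number 2 percentage points higher from compound 1 to compound 3 (within the scatter). For compound 3 the estimated value is 55%, with an expected range from 33% to 77%.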

Compound 3, oral bioavailability: 88%
For compound 3 the middle estimate is 33 percentage points below the measured one, and the stated range ends below it.
By their numbers in this assay, from the lowest: compound 1; then compounds 3 and 2 (each within the scatter of the next).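

Placing trifluoromethyl in place of cyano on the aromatic carbon ortho to the isopropoxy group gives, in this assay, a number 35 percentage points higher from compound 1 to compound 3 (beyond the scatter), so the group at this position can strongly affect how much of the oral dose reaches the circulation. Compound 1 and compound 2 both carry cyano here, so neither could show this. Nothing measured here gives a reason for this step. Going by these compounds, it remains open how a chlorine atom or an amine at this position would compare, and whether the same change would have a similar effect on the core of compound 2.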